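Cinnamoyl sulfonamides: chloro added to the sulfonyl ring

The compounds below may be only part of what the source reports. "The series", "measured", "known", "first", "only" and "open" are said of these compounds alone.

Measured so far in a functional assay on B16-F10 cells (Mus musculus) for antiproliferative activity, read by ELISA and MTT assay, with a stated time of 48 h; on this read-out higher numbers stand for weaker inhibition and lower numbers for stronger inhibition:
compound 1 `O=C(/C=C/c1ccc(F)cc1)NS(=O)(=O)c1ccc(Cl)cc1` gives 2.6 ug/mL
compound 2 `COc1ccc(/C=C/C(=O)NS(=O)(=O)c2ccc(Cl)cc2)cc1` gives 5.3 ug/mL
compound 3 `O=C(/C=C/c1ccc([N+](=O)[O-])cc1)NS(=O)(=O)c1ccccc1` gives 4.8 ug/mL

Compound 3 stands second highest of the three numbers; its gap to compound 2 and its gap to compound 1 are both within the scatter, so the three cannot be ordered. Compound 4 `O=C(/C=C/c1ccc([N+](=O)[O-])cc1)NS(=O)(=O)c1ccc(Cl)cc1` differs from compound 3 in one place: chloro in place of hydrogen on an aromatic carbon. Among the compounds with values here, the only step in the set, a 2.0-fold higher number from compound 1 to compound 2 (0.31 log units; beyond the scatter), concerns the other aromatic ring and does not bear on this change; compounds 1 and 2 already carry the chloro, and the data give no pair that isolates its effect. With nothing pointing either way, no step beyond the scatter is expected, a 1.1-fold lower number from compound 3 to compound 4 (0.03 log units; within the scatter). Compound 4 is therefore estimated at 4.5 ug/mL, with a range of 2 ug/mL to 10 ug/mL in this assay .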

Compound 4, half-maximal inhibitory concentration: 13.7 ug/mL
Compound 4: the middle estimate sits 3.0-fold (0.48 log units) below what was measured; measured number above the stated range.
By their numbers in this assay, from the lowest: compounds 1, 3 and 2 (each within the scatter of the next, the first and the last beyond it); then compound 4.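

In this assay, within the data shown here, the change from phenyl to 4-chlorophenyl is seen in isolation for the first time, and with nitro on the other ring it weakens inhibition (a 2.9-fold higher number from compound 3 to compound 4 (0.46 log units; beyond the scatter)). With the chloro held, nitro reads weaker than methoxy (a 2.6-fold higher number from compound 2 to compound 4 (0.41 log units; beyond the scatter)) and weaker than fluoro (a 5.3-fold higher number from compound 1 to compound 4 (0.72 log units; beyond the scatter)), so compound 4 is the weakest of the four.

As far as these compounds go, whether the chloro step holds with fluoro or methoxy on the other ring stays open, as does how an amine or a carboxylic acid would read in the same place. No available evidence accounts for this step.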